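This account rests on a few compounds, and the source may have more. Where it says the series, first, only, none or still open, it means among the compounds named here.

Measured so far:
- compound 1, `O=C(Nc1ccc(Cl)cc1)NS(=O)(=O)c1ccc(Cl)s1`, in a functional assay on the whole organism (6C3HED cells, Mus musculus) for inhibition, at a dose of 300 mg/kg by the oral route (a lower number here means less inhibition, a higher number more inhibition at the dose given (going by the name of the read-out)), gives 89%
- compound 2, `CSc1ccc(S(=O)(=O)NC(=O)Nc2ccc(Cl)cc2)s1`, in this assay gives 62%
- compound 3, `CCc1ccc(S(=O)(=O)NC(=O)Nc2ccc(Cl)cc2)o1`, in this assay gives 80%

Compound 3 stands second highest of the three numbers: next to it lies compound 1, separated by a number 9 percentage points lower from compound 1 to compound 3 (within the scatter), and furthest away lies compound 2, separated by a number 18 percentage points higher from compound 2 to compound 3 (beyond the scatter). The unmeasured compound 4, `CCc1csc(S(=O)(=O)NC(=O)Nc2ccc(Cl)cc2)c1`, differs from compound 3 only at the sulfonyl sulfur: a group of 7 heavy atoms (6 carbon, 1 sulfur; one five-membered aromatic ring with 1 hetero atom) in place of a group of 7 heavy atoms (6 carbon, 1 oxygen; one five-membered aromatic ring with 1 hetero atom), on a sulfonyl sulfur. The ring that enters carries one sulfur in place of the oxygen of the 5-ethylfuran-2-yl group that leaves.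

Two measured steps also swap the whole group on the sulfonyl sulfur. The change a number 9 percentage points lower from compound 1 to compound 3 (within the scatter) stayed within the scatter, while a number 18 percentage points higher from compound 2 to compound 3 (beyond the scatter) was modest. Because a number 9 percentage points lower from compound 1 to compound 3 (within the scatter) lay within the scatter, exchanging one five-membered aromatic ring with one hetero atom for another is expected to move this assay little, so no step beyond the scatter is expected from compound 3 to compound 4: no change at the digits printed from compound 3 to compound 4 (within the scatter). Compound 4 is therefore estimated at 80%, in a range from 62% to 93%.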

Compound 4, a percentage reported as inhibition, in the whole organism at one dose (the size of the read-out at that dose, not a potency): 93%
Estimate against measurement, compound 4: 13 percentage points below; measured number inside the range.
By their numbers in this assay, from the lowest: compound 2; then compounds 3, 1 and 4 (each within the scatter of the next, the first and the last beyond it).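

In this assay, swapping the oxygen-containing ring for the sulfur-containing ring on the sulfonyl sulfur gives a number 13 percentage points higher from compound 3 to compound 4 (beyond the scatter), so two five-membered aromatic rings of the same heavy-atom count need not read alike at this position. The group of compound 4 also gives a number 4 percentage points higher from compound 1 to compound 4 (within the scatter), which puts it level with the 5-chlorothiophen-2-yl group, and a number 31 percentage points higher from compound 2 to compound 4 (beyond the scatter), the largest step yet seen at this position among these compounds. Nothing available explains why these rings differ.

On these data alone, it remains open how this position would respond to a ring carrying an amine or a carboxylic acid, or to a longer chain such as propyl or butyl in place of ethyl. As far as these compounds go, it is equally open whether a six-membered ring such as phenyl would fit this series.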